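The source may report more compounds than this note shows. Statements on the series, on what has been measured and on what is new or still open speak of the compounds shown alone.

Of the compounds shown here, three of a shared core have been measured for how long they last in an in vitro ADME assay on the whole organism (microsomes, liver, Mus musculus) for metabolic stability, read by LC-MS, with a stated time of 24 h, at a dose of 5 mg/kg by the intravenous route; a higher number here means that the compound lasts longer, a lower number that the compound disappears faster. Compound 1 `O=[N+]([O-])c1cn2c(n1)OC[C@@H](NCc1ccc(OC(F)(F)F)c(Cl)c1)C2` gives 0.223 h in this assay. Compound 2 `CN(Cc1ccc(OC(F)(F)F)cc1)[C@@H]1COc2nc([N+](=O)[O-])cn2C1` gives 0.183 h in this assay, and compound 3 `O=[N+]([O-])c1cn2c(n1)OC[C@@H](NCc1ccc(OC(F)(F)F)cc1Cl)C2` gives 0.332 h in this assay. The number of compound 1 is close to that of compound 2 and close to that of compound 3; both gaps fall within the usual scatter of repeated measurements, so the three compounds cannot be told apart on these figures alone, and none of them can be called the longest or the shortest lasting.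

Compound 4 `O=[N+]([O-])c1cn2c(n1)OC[C@@H](NCc1ccc(OC(F)(F)F)c(Oc3ccccc3)c1)C2` has not yet been measured. It differs from compound 1 in one place: phenoxy in place of chloro on an aromatic carbon. For the measured compounds named here, no measured pair shows this kind of exchange, so no measured step gives a direction. Since all three measured compounds sit within the scatter of one another, no step beyond the scatter is expected from compound 1 to compound 4 in this assay, in either direction. Compound 4 is therefore estimated to give 0.2 h in this assay, with a range from 0.08 h to 0.5 h, which means an expected step of a 1.1-fold lower number from compound 1 to compound 4 (0.05 log units; within the scatter).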

Compound 4, half-life: 0.155 h
Compound 4: middle estimate off by 1.3-fold (0.11 log units), on the high side, within the range that was stated.
By their numbers in this assay, from the lowest: compounds 4, 2, 1 and 3 (each within the scatter of the next, the first and the last beyond it).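

In this assay, for the compounds shown here, the exchange of chloro for phenoxy on the aromatic carbon ortho to a trifluoromethoxy group gives a 1.4-fold lower number from compound 1 to compound 4 (0.16 log units; within the scatter) and so adds a first measured step at this position. The change is large in size, since 1 heavy atom leaves and 7 heavy atoms enter, bringing a six-membered aromatic ring of carbon only and 1 hydrogen-bond acceptor, yet the half-life of compound 4 cannot be told apart from that of compound 1 on these figures, so this position accepts the much larger group with no step beyond the usual scatter in this single pair. Nothing measured here explains this result or ties it to any property of either group.

On these data alone, this is one exchange at one position, so it remains open whether a different group placed there, such as an amine, a carboxylic acid or a longer chain, would give a step beyond the scatter. As far as these compounds go, it also remains open whether the same exchange of chloro for phenoxy would give a similar step on a compound that differs elsewhere from compound 1.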